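Swapping Fluoropiperidine for Oxopiperazine: Expected Hepatic Extraction

The compounds below may be only part of what the source reports. "The series", "measured", "known", "first", "only" and "open" are said of these compounds alone.

Measured so far:
compound 1 `O=C1Cc2cc(-c3c(-c4ccc(F)cc4)nc4c(N5CCC(O)CC5)nccn34)ccc2N1`: 0.4
compound 2 `O=C1Cc2cc(-c3c(-c4ccc(F)cc4)nc4c(N5CCC(F)CC5)nccn34)ccc2N1`: 0.7
compound 3 `O=C1Cc2cc(-c3c(-c4ccc(F)cc4)nn4c(N5CCC(F)CC5)nccc34)ccc2N1`: 0.6

All three were run in an ADME assay on microsomes from liver (Rattus norvegicus), read by LC-MS, with a stated time of 60 min, tested at 1 uM; on this read-out lower numbers stand for lower hepatic extraction and higher numbers for higher hepatic extraction. Compound 3 holds the second highest of the three numbers: compound 2 lies within the scatter of it, while compound 1 lies lower, beyond the scatter.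

Compound 4 `O=C1CN(c2nccc3c(-c4ccc5c(c4)CC(=O)N5)c(-c4ccc(F)cc4)nn23)CCN1` differs from compound 3 in one place: 3-oxopiperazin-1-yl in place of 4-fluoropiperidin-1-yl on an aromatic carbon. For the measured compounds named here, only one measured step speaks to a change of this kind, a number 0.30 higher from compound 1 to compound 2 (beyond the scatter), where a fluoro replaced a hydroxy. In compound 4 the fluorine leaves and a hydrogen-bond donor with a second acceptor enters, so the change runs in the opposite sense, and a modest decrease is expected. Compound 4 is therefore estimated at 0.4, between 0.2 and 0.6. That estimate expects a number 0.20 lower from compound 3 to compound 4 (beyond the scatter).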

Compound 4, hepatic extraction ratio: 0.6
Beside the measured number, compound 4's estimate is 0.20 below it; the measured number falls inside the stated range.
By their numbers in this assay, from the lowest: compound 1; then compounds 3, 4 and 2 (each within the scatter of the next).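

At this aromatic carbon, putting 3-oxopiperazin-1-yl in place of 4-fluoropiperidin-1-yl gives no change at the digits printed from compound 3 to compound 4 (within the scatter) in this assay, so the added hydrogen-bond donor and acceptor leave the read-out unmoved on this core. For the compounds shown here, the earlier step, a number 0.30 higher from compound 1 to compound 2 (beyond the scatter), changed only one group on the saturated ring of a different core, and it does not carry over to this swap of the whole ring. No measurement shown here offers a reason for this result.

Going by these compounds, whether the swap behaves the same way on the core of compound 1 remains open. So does the outcome with other groups at this place, such as morpholine or an open-chain amine.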